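The compounds below may be only part of what the source reports. "The series", "measured", "known", "first", "only" and "open" are said of these compounds alone.

Measured compounds:
compound 1 `c1ccc2c(c1)CN[C@@H](CN(CCCCNCC1CCOCC1)[C@H]1CCCc3cccnc31)C2` — 52.9 nM in a functional assay on cells for antagonist activity at C-X-C chemokine receptor type 4 (Homo sapiens), read by fluorescence and calcium flux, with stated times of 25 min and 90 s; a lower number here means a stronger inhibitor, a higher number a weaker inhibitor
compound 2 `CC(C)(CN)CCN(C[C@H]1Cc2ccccc2CN1)[C@H]1CCCc2cccnc21` — 69 nM in this assay

Within the data shown here, only two compounds have numbers so far, and compound 2 sits within the usual scatter of the other one: the step of a 1.3-fold higher number from compound 1 to compound 2 (0.12 log units; within the scatter) is too small to count as a real difference. That step swapped a large oxygen-containing ring-bearing chain for a short branched chain on the same amine nitrogen, and the readout barely moved.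

Compound 3 `C(=C/CN(C[C@H]1Cc2ccccc2CN1)[C@H]1CCCc2cccnc21)\CNCc1cccnc1` has not yet been measured. It differs from compound 2 by a group of 11 heavy atoms (9 carbon, 2 nitrogen; one six-membered aromatic ring with 1 hetero atom) in place of a group of 6 heavy atoms (5 carbon, 1 nitrogen; no ring), on a saturated chain carbon bound to an amine nitrogen. Among the measured compounds shown here, this is the same place in the molecule that was changed between compound 1 and compound 2, and the new group is closer in size to the one in compound 1 than to the one in compound 2. For the measured compounds named here, the one measured step that bears on this position, from compound 1 to compound 2, was within the scatter, which suggests this part of the molecule tolerates quite different groups without a large shift in this assay. The expected step of a 1.2-fold lower number from compound 2 to compound 3 (0.06 log units; within the scatter) is therefore small, with no clear direction beyond the scatter. Compound 3 is expected to give about 60 nM, estimated within the range 20 nM to 200 nM.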

Compound 3, half-maximal inhibitory concentration: 92.8 nM
For compound 3 the middle estimate is 1.5-fold (0.19 log units) below the measured one; the measured number falls inside the stated range.
By their numbers in this assay, from the lowest: compounds 1, 2 and 3 (each within the scatter of the next).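

In this assay, the group with a six-membered aromatic ring and a double bond outside that ring gives a result close to that of the short open chain with no ring (a 1.3-fold higher number from compound 2 to compound 3 (0.13 log units; within the scatter)). It also stays close to the group with a six-membered non-aromatic ring, which has the same count of 11 heavy atoms (a 1.8-fold higher number from compound 1 to compound 3 (0.24 log units; within the scatter)), so across these three compounds, a group on the saturated chain carbon bound to an amine nitrogen can have no ring, a non-aromatic ring or an aromatic ring without a step beyond the scatter. No further measurement is available to explain this result.

The aromatic ring and the double bond enter together in compound 3, so their separate contributions cannot be told apart from these compounds. All three groups contain nitrogen, which leaves open what a plain butyl chain or a carboxylic acid would do in this place, and whether a much longer chain would still give a result within the scatter.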